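The compounds below may be only part of what the source reports. "The series", "measured", "known", "first", "only" and "open" are said of these compounds alone.

Compound 1 `Cc1cc(Nc2cc(-c3ccccc3)[nH]n2)n2ncnc2n1` stands at the weak end of the numbers shown: in a functional assay on PC-9 cells (Homo sapiens) for inhibition, read by MTT assay, with a stated time of 72 h (a higher number here means a weaker inhibitor, a lower number a stronger inhibitor), compound 1 gives only a limit, > 50000 nM, which is the limit of > 50000 nM in this assay, at which 1 of the 3 values shown sits. Compound 2 `Cc1cc(Nc2cc(-c3ccccc3)[nH]n2)n2nc(SCc3nc4ccccc4[nH]3)nc2n1` carries ((1H-benzimidazol-2-yl)methyl)sulfanyl in place of hydrogen on an aromatic carbon, and in this assay compound 2 gives 4840 nM, so that an at least 10-fold lower number from compound 1 to compound 2 (1.01 log units; beyond the scatter). Compound 3 `Cc1cc(Nc2ccn(Cc3nc(C)c4ccccc4n3)n2)n2nc(SCc3ccc(Br)cc3)nc2n1` is not a single-place neighbour of compound 1; in this assay compound 3 gives 5450 nM. Compound 4 `Cc1cc(Nc2cc(-c3ccccc3)[nH]n2)n2nc(SCc3ccccc3Br)nc2n1` is compound 1 with (2-bromobenzyl)sulfanyl in place of hydrogen on an aromatic carbon. For the measured compounds named here, the one measured step that bears on this change, an at least 10-fold lower number from compound 1 to compound 2 (1.01 log units; beyond the scatter), was large, so for compound 4 a step in this assay of similar size and the same direction is expected, an at least 10-fold lower number from compound 1 to compound 4 (1.00 log units; beyond the scatter). The estimate for compound 4 in this assay is 5000 nM, with a range from 1500 nM to 20000 nM.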

Compound 4, half-maximal inhibitory concentration: 5630 nM
The estimate for compound 4 lay 1.1-fold (0.05 log units) below the measured number; measured number inside the range.
By their numbers in this assay, from the lowest: compounds 2, 3 and 4 (each within the scatter of the next). At a limit, above all of these: compound 1.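

In this assay, a second group on the aromatic carbon between two ring nitrogen atoms also gives a step beyond the scatter, an at least 8.8-fold lower number from compound 1 to compound 4 (0.94 log units; beyond the scatter), so this gain does not depend on the benzimidazole. Compound 1 stands at a limit, so that step is only a bound: the limit of > 50000 nM in this assay, at which 1 of the 4 values shown sits. The two groups at the end of the sulfanyl chain are not told apart here, with a 1.2-fold higher number from compound 2 to compound 4 (0.07 log units; within the scatter).

Still open, as far as these compounds go, is what a plain methylsulfanyl group, an amine or a carboxylic acid would give at this place. Also open, from the compounds shown here alone, is whether the bromine on the benzyl ring contributes anything.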